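The compounds below may be only part of what the source reports. "The series", "measured", "known", "first", "only" and "open" are said of these compounds alone.

In a functional assay on DU-145 cells (Homo sapiens) for inhibition, read by trypan blue exclusion, with a stated time of 96 h (on this read-out higher numbers stand for weaker inhibition of growth and lower numbers for stronger inhibition of growth), the three measured compounds fall into two groups. Compound 1 `O=C(/C(=C\c1c(O)cc(O)cc1O)Sc1ccccc1Br)c1ccc(Br)cc1` reaches only a limit of the assay, > 100000 nM, and the figure is a limit rather than a number (the limit of > 100000 nM in this assay, at which 1 of the 3 values shown sits). Compound 2 `O=C(/C(=C\c1ccc(Cl)cc1)Sc1ccc(Cl)cc1)c1ccc(Cl)cc1` gives 1000 nM. Compound 3 `O=C(/C(=C\c1ccc(OCc2ccccc2)cc1)S(=O)(=O)Cc1ccc(Cl)cc1)c1ccc(Cl)cc1` gives 1000 nM, and compound 2 stands level with it on this read-out, the two values lying within the usual scatter of each other.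

The compound not yet measured is compound 4 `O=C(/C(=C\c1ccc(Cl)cc1)SCc1ccccc1Cl)c1ccc(Cl)cc1`. It differs from compound 2 in one place: 2-chlorobenzyl in place of 4-chlorophenyl on a sulfur. Within the data shown here, no pair of measured compounds shows this particular change, so nothing in the data sets its size. Compound 3 carries a benzyl rather than an aryl group on its sulfur and sits level with compound 2, which gives no sign that a benzyl on sulfur costs potency here. For compound 4 a step from compound 2 of a 1.5-fold higher number from compound 2 to compound 4 (0.18 log units; within the scatter) is expected, meaning little movement beyond the scatter in either direction. Compound 4 is therefore estimated at 1500 nM, with a range from 400 nM to 6000 nM.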

Compound 4, concentration for 50% growth inhibition: 12000 nM
Compound 4: the middle estimate sits 8.0-fold (0.90 log units) below what was measured; measured number above the stated range.
By their numbers in this assay, from the lowest: compounds 2 and 3 (each within the scatter of the next); then compound 4. At a limit, above all of these: compound 1.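

In this assay the group on this sulfur proves to matter: 2-chlorobenzyl in place of 4-chlorophenyl reads as a 12-fold higher number from compound 2 to compound 4 (1.08 log units; beyond the scatter) and lies beyond the scatter. Among these compounds, this is the first step that can be read at a single place, as the earlier compounds offered no pair differing only here and so showed nothing of how this sulfur position responds to change. Nothing in the data shown accounts for the size of this step.

Still open, going by these compounds, is whether the step belongs to the benzyl or to the place of the chlorine, which 4-chlorobenzyl or 2-chlorophenyl on this sulfur would separate. Also open, on these data alone, is how an unsubstituted benzyl, or a longer chain such as 2-phenylethyl, would read on the same sulfur.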